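This account rests on a few compounds, and the source may have more. Where it says the series, first, only, none or still open, it means among the compounds named here.

Going by the values given here, compound 3 `COc1ccc(-c2nc(CN(C)C)sc2-c2ccc(OC)cc2)cc1` is the one member of this set with a number in a functional assay with Oryctolagus cuniculus as the target; a higher number here means a weaker inhibitor, a lower number a stronger inhibitor: compound 3 gives 96 nM. Compound 1 `COc1ccc(-c2nc(/N=C(\N)NC(C)C)sc2-c2ccc(OC)cc2)cc1` gives only a limit of the assay, > 100 nM. Compound 2 `COc1ccc(-c2nc(/N=C(\N)NC3CCCCC3)sc2-c2ccc(OC)cc2)cc1` likewise gives only a limit, > 1000 nM. Compound 4 `COc1ccc(-c2nc(CNC(=O)c3cccnc3)sc2-c2ccc(OC)cc2)cc1` carries ((pyridin-3-yl)carbonyl)amino in place of dimethylamino on a saturated chain carbon bound to an aromatic carbon. The measured steps alter the group on the aromatic carbon, not this chain carbon, so they bear only loosely on it; still, an at least 1.0-fold lower number from compound 1 to compound 3 (0.01 log units; that floor lies within the scatter) and an at least 10-fold lower number from compound 2 to compound 3 (1.01 log units; beyond the scatter) both accompany a move to a smaller group. Because compound 3 gained with an at least 10-fold lower number from compound 2 to compound 3 (1.01 log units; beyond the scatter) when a bulky group was removed, compound 4, which adds bulk, is expected to be somewhat weaker, by a 3.1-fold higher number from compound 3 to compound 4 (0.49 log units; beyond the scatter). Compound 4 is therefore estimated at 300 nM, between 80 nM and 1500 nM.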

Compound 4, half-maximal inhibitory concentration: 25 nM
Beside the measured number, compound 4's estimate is 12-fold (1.08 log units) above it, and the stated range ends above it.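

On a saturated chain carbon bound to an aromatic carbon, ((pyridin-3-yl)carbonyl)amino in place of dimethylamino gives a 3.8-fold lower number from compound 3 to compound 4 (0.58 log units; beyond the scatter) in this assay, so at this position the larger group goes with the stronger inhibitor. The steps of an at least 40-fold lower number from compound 2 to compound 4 (1.60 log units; beyond the scatter) and an at least 4.0-fold lower number from compound 1 to compound 4 (0.60 log units; beyond the scatter) are only floors, set by limits of the assay. No measurement shown gives a reason for the gain.

On these data alone, it remains open whether the gain depends on the pyridin-3-yl ring, the carbonyl or the amide hydrogen. A benzoyl amide, an acetyl amide or a primary amine on this chain carbon would help separate these parts.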